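This account rests on a few compounds, and the source may have more. Where it says the series, first, only, none or still open, it means among the compounds named here.

Of the compounds shown here, three have been tested in an ADME assay on BJ cells (Homo sapiens) for cytotoxicity, read by CellTiter-Glo and resazurin assay, with a stated time of 72 h; on this read-out higher numbers stand for an effect only at larger amounts of compound and lower numbers for an effect already at smaller amounts. Compound 1 `CC(C)N(Cc1cccc(OCCCCCC(=O)O)c1)C(=O)c1ccc(-c2ccoc2)cc1` gives > 26000 nM there, which is a limit of the assay and not a number. Compound 2 `CC(C)N(Cc1cccc(OCCCCCC(=O)O)c1)C(=O)c1ccc(-c2cccc(OC(F)(F)F)c2)cc1` likewise gives > 26000 nM, again a limit. The step that the two limits leave unreadable from compound 1 to compound 2 is therefore unreadable. Compound 3 `CCOC(=O)CCCCCOc1cccc(CN(C(=O)c2ccc(-c3cccc(N(C)C)c3)cc2)C(C)C)c1` stands at > 26000 nM in this assay, also a limit, so no number places it among the others; as the limit of > 26000 nM in this assay, at which 3 of the 3 values shown sit, shows, every value in hand sits at that limit. Compound 4 `CCOC(=O)CCCCCOc1cccc(CN(C(=O)c2ccc(-c3cccc(OC)c3)cc2)C(C)C)c1` is not yet measured. It differs from compound 3 by methoxy in place of dimethylamino on an aromatic carbon. Within the data shown here, none of the measured steps carries this change, and the only measured step is unreadable from two limits, so no size can be read for it. Because compound 3 sits at the limit of > 26000 nM, the step that the limit leaves unreadable from compound 3 to compound 4 is expected to be nil within the scatter. Compound 4 is therefore estimated at 40000 nM in this assay, within 20000 nM to 100000 nM, with a limit the likelier outcome.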

Compound 4, half-maximal effective concentration: > 21000 nM
Compound 4: a limit, no number (the forecaster's own chance of this, stated with the estimate: 85%); the middle value lies beyond the limit too.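

Compound 3 and compound 4 both stand at limits of the assay and not at numbers, and no step can be read between them. The compounds shown leave open at what concentration, if any, a measurable effect appears in this assay.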